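The source may hold more compounds than are shown below. What is called first, only, known or untested is meant among the compounds shown, and "the series" means these compounds.

In a functional assay on NCI-H522 cells (Homo sapiens) for inhibition, read by sulforhodamine B assay, with a stated time of 48 h (a higher number here means a weaker inhibitor of growth, a lower number a stronger inhibitor of growth), compound 2 `Cc1cc(O)ccc1C1=NN(c2ccc(S(C)(=O)=O)cc2)C(=O)CC1` gives 8600 nM, the higher of the two numbers measured, while compound 1 `Cc1ccc(C2=NN(c3ccc(S(C)(=O)=O)cc3)C(=O)CC2)cc1` gives 1000 nM. Compound 3 `CCc1ccc(C2=NN(c3ccc(S(C)(=O)=O)cc3)C(=O)CC2)cc1` carries 4-ethylphenyl in place of 4-hydroxy-2-methylphenyl on a carbon with a double bond to nitrogen. Going by the values given here, the only measured step that bears on this change is an 8.6-fold higher number from compound 1 to compound 2 (0.93 log units; beyond the scatter), which brought in the group that now leaves. Much of that step is expected to reverse. The expected move, toward a lower number and of similar size, is a 7.2-fold lower number from compound 2 to compound 3 (0.86 log units; beyond the scatter). For compound 3 the estimated value is 1200 nM, with an expected range of 400 nM to 3500 nM.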

Compound 3, concentration for total growth inhibition: 8370 nM
Beside the measured number, compound 3's estimate is 7.0-fold (0.84 log units) below it; the measured number lies above the stated range.
By their numbers in this assay, from the lowest: compound 1; then compounds 3 and 2 (each within the scatter of the next).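

In this assay, the 4-ethylphenyl group, with no hydrogen-bond donor, stands level with 4-hydroxy-2-methylphenyl at this place, as a 1.0-fold lower number from compound 2 to compound 3 (0.01 log units; within the scatter) shows. The loss of the hydroxy group therefore does not by itself bring the number back toward that of compound 1. Lengthening the 4-substituent by a single methyl gives an 8.4-fold higher number from compound 1 to compound 3 (0.92 log units; beyond the scatter), so this position distinguishes even 4-methylphenyl from 4-ethylphenyl. Nothing available explains this sensitivity. From the compounds shown here alone, whether a smaller group such as unsubstituted phenyl or 4-fluorophenyl would give a lower number than compound 1 stays open.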